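Trifluoromethoxy for tert-butyl on a quinoline urea

This account rests on a few compounds, and the source may have more. Where it says the series, first, only, none or still open, it means among the compounds named here.

Compound 1 `Cc1cc(NC(=O)Nc2ccc(C(C)(C)C)cc2)c2ccccc2n1` — in an ADME assay on Raji cells (Homo sapiens) for cytotoxicity, with a stated time of 72 h (on this read-out higher numbers stand for an effect only at larger amounts of compound and lower numbers for an effect already at smaller amounts), compound 1 gives > 25000 nM, which is a limit of the assay rather than a number.
Compound 2 `COc1ccc(NC(=O)Nc2cc(C)nc3ccccc23)cc1Cl` — in this assay compound 2 gives > 25000 nM, again a limit.
Compound 3 `Cc1cc(NC(=O)Nc2ccccc2C(N)=O)c2ccccc2n1` — in this assay compound 3 gives > 25000 nM, also a limit.

Within the data shown here, compound 1 therefore stands nowhere in particular among its neighbours: every value so far sits at the limit of > 25000 nM in this assay, at which 3 of the 3 values shown sit, and the measurement reports no effect up to that point for any of the three. Among the measured compounds shown here, no step between two measured compounds exists, so nothing shows how a change on the outer ring moves the read-out.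

Compound 4 `Cc1cc(NC(=O)Nc2ccc(OC(F)(F)F)cc2)c2ccccc2n1` differs from compound 1 by trifluoromethoxy in place of tert-butyl on an aromatic carbon.

With every measured value at the limit, the step from compound 1 to compound 4 is expected to be none beyond the scatter, a step that the limit leaves unreadable from compound 1 to compound 4, and compound 4 is expected most likely to come back as a limit as well. The estimate for compound 4 is 40000 nM, with a range from 15000 nM to 120000 nM.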

Compound 4, half-maximal effective concentration: 10000 nM
Estimate against measurement, compound 4: 4.0-fold (0.60 log units) above, outside the stated range (below it).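

In this assay, putting trifluoromethoxy in place of tert-butyl gives an at least 2.5-fold lower number from compound 1 to compound 4 (0.39 log units; beyond the scatter), so this aromatic carbon, para to a large group, is a place where changing one group can bring a measurable effect into range. As far as these compounds go, compound 1 gives > 25000 nM, which is a limit, so the step shows a direction and a smallest size, while its full size stays unknown. Compound 4 is the only compound shown with a real number rather than a limit, and it gives the series its first point of comparison: the limit of > 25000 nM in this assay, at which 3 of the 4 values shown sit.

A single step cannot tell which feature of trifluoromethoxy matters, or whether the change would have the same effect on the other compounds. From the compounds shown here alone, it also remains open how an amine, a carboxylic acid or a longer alkyl chain on the same carbon would behave in this assay.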